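This account rests on a few compounds, and the source may have more. Where it says the series, first, only, none or still open, it means among the compounds named here.

Measured so far:
compound 1, `N#Cc1cnc(NC(=O)CCCOc2cccc(Cl)c2)s1` — 0.25 h
compound 2, `Cc1cnc(NC(=O)CCCOc2cccc(C#N)c2)s1` — 0.167 h

Both compounds were tested in an ADME assay on microsomes from liver (Homo sapiens) for metabolic stability, read by LC-MS, using NADPH, tested at 1 uM (on this read-out lower numbers stand for a shorter-lived compound and higher numbers for a longer-lived compound), a test of how quickly a compound is broken down by liver enzymes. In this assay compound 1 gives 0.25 h, and compound 2 gives 0.167 h. Of the two numbers, that of compound 2 is the lower one, but its distance from compound 1 lies within the usual scatter of the test, so the two results cannot truly be told apart: both compounds are short-lived.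

Compound 3, `Cc1cnc(NC(=O)CCCOc2ccccc2)s1`, has not yet been measured in this assay. It differs from compound 2 in a single place, (hydrogen in place of cyano on an aromatic carbon). Going by the values given here, no measured pair here shows what such a change does, so the only guide is that the two measured compounds, which share the same core and chain and differ only in their ring substituents, sit close together.

On that basis the step from compound 2 to compound 3 is expected to be small, a 1.1-fold lower number from compound 2 to compound 3 (0.05 log units; within the scatter), with no direction beyond the scatter. Compound 3 is therefore expected to give about 0.15 h, with a likely range from 0.07 h to 0.35 h.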

Compound 3, half-life in the Homo sapiens assay: 0.167 h
The estimate for compound 3 lay 1.1-fold (0.05 log units) below the measured number; the range from low to high includes it.
By their numbers in the Homo sapiens assay, from the lowest: compounds 2, 3 and 1 (each within the scatter of the next).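

Going by these compounds alone, in the Homo sapiens assay, hydrogen in place of cyano on an aromatic carbon gives no change at the digits printed from compound 2 to compound 3 (within the scatter), so this pair offers the first direct look at a single change at this place, and here the half-life does not tell the two groups apart. In a physicochemical assay for solubility, read by nephelometry, in phosphate buffer, at pH 6.5 (a lower number here means a less soluble compound, a higher number a more soluble compound), compound 2 gives < 1100 nM, which is a limit of the assay and not a number. In the physicochemical assay compound 3 gives < 1100 nM, which is likewise a limit of the assay.

The step in solubility from one compound to the other therefore cannot be read, because both compounds sit at the same limit: the limit of < 1100 nM in the physicochemical assay, at which 2 of the 2 values shown sit. Still open is whether another group at this place on the six-membered aromatic ring, such as an amine or a carboxylic acid, or a longer chain between the amide and the ring oxygen, would carry the half-life in the Homo sapiens assay clear of the scatter, since all three compounds shown so far remain short-lived.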